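Swapping the pendant para group for a dichlorophenyl

The compounds below may be only part of what the source reports. "The series", "measured", "known", "first", "only" and "open" are said of these compounds alone.

Measured compounds in an assay on isolated protein for inhibition of ATP-citrate synthase (Homo sapiens); a lower number here means a stronger inhibitor, a higher number a weaker inhibitor:
compound 1, `O=C(O)C[C@@](O)(C[C@H](O)CCCCCCc1ccc(Cl)cc1-c1ccc(F)cc1)C(=O)O`, gives 2700 nM;
compound 2, `Cc1ccc(-c2cc(Cl)ccc2CCCCCC[C@@H](O)C[C@](O)(CC(=O)O)C(=O)O)cc1`, gives 2700 nM;
compound 3, `COc1ccc(-c2cc(Cl)ccc2CCCCCC[C@@H](O)C[C@](O)(CC(=O)O)C(=O)O)cc1`, gives 5100 nM.

Compound 3 has the highest of the three numbers, but both of its neighbours sit within the scatter of it: a 1.9-fold higher number from compound 1 to compound 3 (0.28 log units; within the scatter) and a 1.9-fold higher number from compound 2 to compound 3 (0.28 log units; within the scatter), and likewise no change at the digits printed from compound 1 to compound 2 (within the scatter). Compound 4, `O=C(O)C[C@@](O)(C[C@H](O)CCCCCCc1ccc(Cl)cc1-c1ccc(Cl)cc1Cl)C(=O)O`, differs from compound 3 by 2,4-dichlorophenyl in place of 4-methoxyphenyl on an aromatic carbon. The three measured steps all change the same part of the molecule and none moved this assay beyond the scatter, so a similar outcome is expected here, with the step of a 1.5-fold lower number from compound 3 to compound 4 (0.16 log units; within the scatter) not expected to exceed the scatter. Compound 4 is therefore estimated at 3500 nM, in a range from 1200 nM to 10000 nM.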

Compound 4, inhibition constant: 21000 nM
Beside the measured number, compound 4's estimate is 6.0-fold (0.78 log units) below it; the whole stated range lies below it.
By their numbers in this assay, from the lowest: compounds 1, 2 and 3 (each within the scatter of the next); then compound 4.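

This position is less forgiving than compounds 1, 2 and 3 suggested: in this assay, 2,4-dichlorophenyl gives (a 4.1-fold higher number from compound 3 to compound 4 (0.61 log units; beyond the scatter)), (a 7.8-fold higher number from compound 2 to compound 4 (0.89 log units; beyond the scatter)) and (a 7.8-fold higher number from compound 1 to compound 4 (0.89 log units; beyond the scatter)). Going by these compounds alone, these are the first steps here beyond the scatter, and all three point towards a weaker inhibitor. Nothing available explains this loss.

On these data alone, whether both chloro groups are needed for the loss stays open, and a phenyl ring carrying a single chloro group would test that. As far as these compounds go, how an amine or a carboxylic acid on this ring would behave in this assay also stays open.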